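A few compounds are considered here, and "the series" means these few. Any claim that something is new, unique, unknown or untested is made for them only; others in the source may bear on it.

Compound 3 `O=S(=O)(Nc1ccc(-c2nc3ccccc3o2)cc1)c1ccccc1O` is one of three compounds tested in an assay on cells for inhibition of HSP60/HSP10 (Homo sapiens), with a stated time of 60 min; a higher number here means a weaker inhibitor, a lower number a stronger inhibitor. In this assay compound 3 gives only the limit > 100000 nM, not a number. Compound 2 `CS(=O)(=O)Nc1ccc(-c2nc3ccccc3o2)cc1` likewise reaches only the limit > 100000 nM in this assay. Compound 1 `O=S(=O)(Nc1ccc(-c2nc3ccccc3o2)cc1)c1cccc(F)c1` gives 71000 nM in this assay. The shared core of all three carries a sulfonamide; the step from compound 1 to compound 3 in this assay is an at least 1.4-fold higher number from compound 1 to compound 3 (0.14 log units; that floor lies within the scatter), that from compound 1 to compound 2 is an at least 1.4-fold higher number from compound 1 to compound 2 (0.14 log units; that floor lies within the scatter), and that from compound 2 to compound 3 is a step that the two limits leave unreadable from compound 2 to compound 3, two values sitting at the limit of > 100000 nM in this assay, at which 2 of the 3 values shown sit. Compound 4 `CCc1ccc(S(=O)(=O)Nc2ccc(-c3nc4ccccc4o3)cc2)cc1` differs from compound 3 by 4-ethylphenyl in place of 2-hydroxyphenyl on a sulfonyl sulfur. Since every measured step lies within the scatter or is unreadable, compound 4 is expected to land near the same weak range, with an estimated value of 80000 nM (between 30000 nM and 200000 nM), an expected step of an at least 1.2-fold lower number from compound 3 to compound 4 (0.09 log units; that floor lies within the scatter).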

Compound 4, half-maximal inhibitory concentration: > 100000 nM
Compound 4: a limit, no number (the forecaster's own chance of this, stated with the estimate: 45%); at least 1.2-fold (0.09 log units) between middle value and limit.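

In this assay, 4-ethylphenyl becomes the third group on the sulfonyl sulfur to give only a limit, and it carries no hydrogen-bond donor, unlike 2-hydroxyphenyl. Among these compounds, the only readable step is an at least 1.4-fold higher number from compound 1 to compound 4 (0.14 log units; that floor lies within the scatter), and the steps to compound 4 from compound 2 and compound 3 cannot be read. Compound 1 remains the only compound with a number, and the limit is now widely shared: the limit of > 100000 nM in this assay, at which 3 of the 4 values shown sit.

On these data alone, whether 3-fluorophenyl truly differs from the other groups remains open. So does whether a phenyl bearing an amine or a carboxylic acid would give a number.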